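The compounds below may be only part of what the source reports. "The series", "measured", "known", "first", "only" and "open" are said of these compounds alone.

Compound 1 `CC(C)[C@@H]1CC[C@@H](C)C[C@@]12N(C)C(=O)[C@@H]1[C@H]3C(=O)NC(=O)[C@H]3ON12` stands highest of the two compounds measured in a functional assay, with a stated time of 20 min, tested at 2 mg/mL; a higher number here means a stronger effect of the compound at the concentration tested, a lower number a weaker effect; in this assay compound 1 gives 58.7%. For the measured compounds named here, its only measured neighbour, compound 2 `CC(C)[C@@H]1CC[C@@H](C)C[C@@]12N(C)C(=O)[C@@H]1[C@H]3C(=O)N(c4ccc(Cl)cc4)C(=O)[C@H]3ON12`, gives 48.2%. The step of a number 10.5 percentage points lower from compound 1 to compound 2 (beyond the scatter) is what 4-chlorophenyl in place of hydrogen on an amide-type nitrogen in a ring brought about.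

Compound 3 `Cc1ccc(N2C(=O)[C@H]3[C@H](ON4[C@@H]3C(=O)N(C)[C@@]43C[C@H](C)CC[C@H]3C(C)C)C2=O)c(C)c1` differs from compound 1 in a comparable way: 2,4-dimethylphenyl in place of hydrogen on an amide-type nitrogen in a ring. Going by the values given here, the only step that bears on this change is the one from compound 1 to compound 2, where a six-membered aromatic ring of carbon only also entered on the same nitrogen and the activity fell modestly, beyond the scatter. A drop of about the same size, a number 11.7 percentage points lower from compound 1 to compound 3 (beyond the scatter), is therefore expected here. The estimate for compound 3 is 47%, with a range from 32% to 62%.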

Compound 3, a percentage reported as activity, at one concentration (the size of the read-out at that concentration, not a potency): 72%
For compound 3 the middle estimate is 25 percentage points below the measured one; the whole stated range lies below it.
By their numbers in this assay, from the lowest: compound 2; then compound 1; then compound 3.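

An aryl group on this amide-type nitrogen does not move the read-out in this assay in one fixed direction: with 2,4-dimethylphenyl in place of hydrogen there is a number 13.3 percentage points higher from compound 1 to compound 3 (beyond the scatter), whereas 4-chlorophenyl had lowered it. What the six-membered aromatic ring carries therefore matters at this position, as the exchange of one aryl group for the other shows, with a number 23.8 percentage points higher from compound 2 to compound 3 (beyond the scatter). No measurement at hand explains why the two groups differ.

The two aryl groups differ in more than one respect, so the compounds shown cannot separate the loss of the chlorine from the gain of the two methyl groups. Going by these compounds, how a plain phenyl, a 4-methylphenyl or a non-aromatic group such as cyclohexyl would behave on this nitrogen also remains open.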